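The source may hold more compounds than are shown below. What is called first, only, known or untested is meant among the compounds shown, and "the series" means these compounds.

Series values in a functional assay on MCF7 cells (Homo sapiens) for cytotoxicity, read by MTT assay, with a stated time of 48 h; a higher number here means a weaker inhibitor, a lower number a stronger inhibitor:
- compound 1 `O=C1/C(=C\c2ccc(O)cc2)S/C(=N/c2ccccc2)N1Cc1ccncc1`: 18900 nM
- compound 2 `COc1cc(/C=C2/S/C(=N/c3ccccc3)N(Cc3ccncc3)C2=O)ccc1O`: 28000 nM

Only these two compounds have been measured so far, and compound 2, at 28000 nM, lies within the scatter of compound 1. Compound 3 `CCOc1cc(/C=C2/S/C(=N/c3ccccc3)N(Cc3ccncc3)C2=O)ccc1O` is the next to be read. Its difference from compound 2 is methyl in place of hydrogen on a saturated chain carbon bound to an oxygen on an aromatic ring, so methoxy becomes ethoxy.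

Among the compounds with values here, one measured step bears on this, and only loosely: a 1.5-fold higher number from compound 1 to compound 2 (0.17 log units; within the scatter). That step put methoxy in place of hydrogen on an aromatic carbon, which is a different change. With nothing else to go on, no shift beyond the scatter is expected in this assay, in either direction. The estimated step is a 1.0-fold lower number from compound 2 to compound 3 (0.02 log units; within the scatter). Compound 3 is expected at 27000 nM, with an estimated range of 13000 nM to 55000 nM.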

Compound 3, half-maximal inhibitory concentration: 20100 nM
For compound 3 the middle estimate is 1.3-fold (0.13 log units) above the measured one; low and high end bracket the measured number.
By their numbers in this assay, from the lowest: compounds 1, 3 and 2 (each within the scatter of the next).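

In this assay, the change from methoxy to ethoxy gives a 1.4-fold lower number from compound 2 to compound 3 (0.14 log units; within the scatter), so one added methyl on the saturated chain carbon bound to an oxygen on an aromatic ring leaves the reading within the scatter. Measured against hydrogen on the same aromatic carbon, ethoxy gives a 1.1-fold higher number from compound 1 to compound 3 (0.03 log units; within the scatter), so now both methoxy and ethoxy have been read there, and neither step goes beyond the scatter. No measurement is available that would account for these readings.

On these data alone, whether a longer chain such as butoxy, a branched isopropoxy, or a chain ending in an amine or a carboxylic acid would move the number beyond the scatter remains open. Within the data shown here, with no step yet beyond the scatter, these compounds do not show which part of the structure governs the reading.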